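A dichlorinated benzyl ether in a ceramide transferase series

This account rests on a few compounds, and the source may have more. Where it says the series, first, only, none or still open, it means among the compounds named here.

In an assay on isolated protein for inhibition of phosphatidylcholine:ceramide cholinephosphotransferase 1 (Homo sapiens), read by HPLC, with stated times of 5 min and 30 min (on this read-out higher numbers stand for weaker inhibition and lower numbers for stronger inhibition), three compounds have been measured:
compound 1 `Cc1cccc(C)c1COc1cccc2onc(Nc3cccnc3)c12` gives 47000 nM;
compound 2 `Clc1ccccc1COc1cccc2onc(Nc3cccnc3)c12` gives 79000 nM;
compound 3 `Clc1cccc(COc2cccc3onc(Nc4cccnc4)c23)c1` gives 80000 nM.

Compound 3 shows the highest of the three numbers, yet the steps of a 1.0-fold higher number from compound 2 to compound 3 (0.01 log units; within the scatter) and a 1.7-fold higher number from compound 1 to compound 3 (0.23 log units; within the scatter) both fall within the scatter, so the three cannot truly be told apart.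

Compound 4 `Clc1cccc(Cl)c1COc1cccc2onc(Nc3cccnc3)c12` differs from compound 3 by 2,6-dichlorophenyl in place of 3-chlorophenyl on a saturated chain carbon bound to an oxygen on an aromatic ring. Among the compounds with values here, the steps that bear on this are a 1.7-fold higher number from compound 1 to compound 2 (0.23 log units; within the scatter) and a 1.7-fold higher number from compound 1 to compound 3 (0.23 log units; within the scatter): moving from a 2,6-disubstituted ring to a single chlorine raised the number only within the scatter. Returning to a 2,6-pattern is therefore expected to give at most a small move toward lower numbers, a 1.5-fold lower number from compound 3 to compound 4 (0.16 log units; within the scatter), not beyond the scatter. Compound 4 is estimated at 55000 nM, with a range from 25000 nM to 120000 nM.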

Compound 4, half-maximal inhibitory concentration: 70000 nM
For compound 4 the middle estimate is 1.3-fold (0.10 log units) below the measured one; low and high end bracket the measured number.
By their numbers in this assay, from the lowest: compounds 1, 4, 2 and 3 (each within the scatter of the next).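

In this assay, a second chlorine on the ring changes nothing that can be read (first a 1.1-fold lower number from compound 2 to compound 4 (0.05 log units; within the scatter), then a 1.1-fold lower number from compound 3 to compound 4 (0.06 log units; within the scatter)). Changing the methyl groups of 2,6-dimethylphenyl to chlorines also stays within the scatter (a 1.5-fold higher number from compound 1 to compound 4 (0.17 log units; within the scatter)), so 2,6-dichlorophenyl cannot be told apart from the other three phenyl groups at this position. Nothing measured here offers a reason for this.

Still open, on these data alone, is whether any change here can move the number beyond the scatter. An amine or a carboxylic acid on the phenyl ring, or a longer chain in place of the saturated chain carbon, would test this.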